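Urea series cytotoxicity: removing one fluoro from compound 2

The compounds below may be only part of what the source reports. "The series", "measured", "known", "first", "only" and "open" are said of these compounds alone.

Two compounds of this series carry results so far. Compound 1 `COc1ccc(NC(=O)Nc2cc(C)nc3ccccc23)cc1` gives in an ADME assay on BJ cells (Homo sapiens) for cytotoxicity, with a stated time of 72 h (a lower number here means that less compound is needed, a higher number that more compound is needed for the effect), only a limit, > 25000 nM. Compound 2 `Cc1cc(NC(=O)Nc2cc(F)ccc2F)c2ccccc2n1` gives 7000 nM in this assay. Compound 2 thus holds the only actual number shown; the other entry is a limit, as recorded in the limit of > 25000 nM in this assay, at which 1 of the 2 values shown sits. Among the compounds with values here, no two measured compounds differ in a single place, so no measured step is available for comparison.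

Compound 3 `Cc1cc(NC(=O)Nc2ccccc2F)c2ccccc2n1` is not yet measured. It differs from compound 2 by hydrogen in place of fluoro on an aromatic carbon. With no measured step of this kind in hand, the expectation rests on compound 2 alone: the loss of one fluoro is expected to shift the readout little, so the step of a 1.3-fold higher number from compound 2 to compound 3 (0.11 log units; within the scatter) is expected to stay within scatter, leaning if anything toward a higher number. Compound 3 is therefore estimated at 9000 nM in this assay, with a range of 3500 nM to 25000 nM.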

Compound 3, half-maximal effective concentration: > 25000 nM
Compound 3: only a limit was reported; the forecaster's own chance of this, stated with the estimate: 20%; middle value at least 2.7-fold (0.44 log units) away from the limit.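

Within the data shown here, this position, on an aromatic carbon meta to a large group and para to a fluoro group, gives the first single-place comparison: in this assay, hydrogen in place of fluoro gives an at least 3.5-fold higher number from compound 2 to compound 3 (0.55 log units; beyond the scatter). For compound 3 the entry > 25000 nM is a limit, not a number, so the step has a floor but no measured size. This one fluoro is the only difference between the two compounds, and most of the series shown now reads at the limit: the limit of > 25000 nM in this assay, at which 2 of the 3 values shown sit.

On these data alone, how far compound 3 lies past its limit stays open, as does whether the step depends on the remaining fluoro group. Also open, as far as these compounds go, is whether chloro or an amine at this position would read like fluoro or like hydrogen.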